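Shortening a side chain: expected cytotoxicity of compound 3

A few compounds are considered here, and "the series" means these few. Any claim that something is new, unique, unknown or untested is made for them only; others in the source may bear on it.

Compound 1 `CCCCCCCC#Cc1cc2cn(COCCO)c(=O)nc2o1` was tested in a functional assay on HEL cells (Homo sapiens); on this read-out higher numbers stand for lower toxicity in this test and lower numbers for higher toxicity in this test. In that assay compound 1 gives only a limit of > 50000 nM, not a number. A second compound, compound 2 `CO[C@H]1[C@H](O)[C@@H](O)[C@@H](O)O[C@@H]1C(=O)O`, gives in this assay a value of 130000 nM. Among the measured compounds shown here, no step between measured compounds that differ in a single place is available, so the only evidence on where compound 1 stands is the limit of > 50000 nM in this assay, at which 1 of the 2 values shown sits.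

Compound 3 `CCCCCC#Cc1cc2cn(COCCO)c(=O)nc2o1` has not yet been measured in this assay. It differs from compound 1 by hydrogen in place of ethyl on a saturated chain carbon, five bonds along the chain from a triple-bonded carbon: ethyl leaves, hydrogen enters, and neither hydrogen-bond donors nor acceptors nor net charge change. With compound 1 standing at the limit of > 50000 nM in this assay, at which 1 of the 2 values shown sits, the step in this assay is expected to stay within the scatter, or at most to be small in either direction. Compound 3 is therefore expected to give 60000 nM, within a range of 30000 nM to 150000 nM. The estimated step from compound 1 to compound 3 is a step that the limit leaves unreadable from compound 1 to compound 3, and the assay is expected most often to report only a limit for compound 3 as well.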

Compound 3, half-maximal cytotoxic concentration: > 50000 nM
Compound 3 ended at the assay's limit (the forecaster's own chance of this, stated with the estimate: 70%); the middle value does not contradict the limit.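

In this assay compound 1 and compound 3 both end at a limit and not at a number, so no step between them can be read: the limit of > 50000 nM in this assay, at which 2 of the 3 values shown sit.

The compounds shown leave open what the half-maximal cytotoxic concentration of compound 1 and compound 3 actually is, and whether hydrogen in place of ethyl changes it at all.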